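A few compounds are considered here, and "the series" means these few. Any claim that something is new, unique, unknown or untested is made for them only; others in the source may bear on it.

Measured so far in a functional assay for inhibition, with Homo sapiens as the target; a higher number here means a weaker inhibitor, a lower number a stronger inhibitor:
- compound 1 `CC(C)(C)Sc1c(CC(C)(C)C(=O)O)n(Cc2ccc(Cl)cc2)c2ccc(OCc3nc4ccccc4s3)cc12`: 3 nM
- compound 2 `CC(C)(C)Sc1c(CC(C)(C)C(=O)O)n(Cc2ccc(Cl)cc2)c2ccc(OCc3nc4cc(C(F)(F)F)ccc4s3)cc12`: 22 nM

Compound 1 has the lowest number of the two, which makes it the stronger inhibitor in this assay. The next compound to consider, compound 3 `CC(COc1ccc2c(c1)c(SC(C)(C)C)c(CC(C)(C)C(=O)O)n2Cc1ccc(Cl)cc1)c1ccccn1`, has not been measured. Its change is 1-(pyridin-2-yl)ethyl in place of 1,3-benzothiazol-2-yl on a saturated chain carbon bound to an oxygen on an aromatic ring: 1-(pyridin-2-yl)ethyl in place of 1,3-benzothiazol-2-yl. Among the compounds with values here, only one measured step bears on this, and it alters the same group: a 7.3-fold higher number from compound 1 to compound 2 (0.87 log units; beyond the scatter), a modest step that lies beyond the scatter. That step adds trifluoromethyl to the group, while compound 3 replaces the group entirely, so it is only a rough guide. It does suggest that changes here can weaken compound 1, and no measured change has lowered its number. The expected step is a 5.0-fold higher number from compound 1 to compound 3 (0.70 log units; beyond the scatter), similar in size to the measured one. For compound 3 the estimated value is 15 nM, with an expected range from 3 nM to 80 nM.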

Compound 3, half-maximal inhibitory concentration: 4 nM
Compound 3: the middle estimate sits 3.8-fold (0.57 log units) above what was measured; low and high end bracket the measured number.
By their numbers in this assay, from the lowest: compounds 1 and 3 (each within the scatter of the next); then compound 2.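

In this assay the swap gives a 1.3-fold higher number from compound 1 to compound 3 (0.12 log units; within the scatter), so a low number at this position does not depend on the whole 1,3-benzothiazol-2-yl group. The 1-(pyridin-2-yl)ethyl group that enters carries a single six-membered aromatic ring and no sulfur, yet the number stays within the scatter. The only earlier step at this position, adding trifluoromethyl to the group, gave a 7.3-fold higher number from compound 1 to compound 2 (0.87 log units; beyond the scatter), so the position accepts this full replacement even though that smaller change moved the number beyond the scatter, and no measurement shown explains this difference.

The compounds shown leave open whether the pyridine nitrogen matters, which a 1-phenylethyl group on the same saturated chain carbon would test. They also leave open whether the ethyl branch matters, which a pyridin-2-ylmethyl group would test.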